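Removing the phenyl chloro in the amide series

A few compounds are considered here, and "the series" means these few. Any claim that something is new, unique, unknown or untested is made for them only; others in the source may bear on it.

Compound 1 `CCCC(=O)NC(c1ccccc1Cl)c1cc(Cl)c2cccnc2c1O` is the reference point of this set. In a functional assay on A-375 cells (Homo sapiens) for antiproliferative activity, read by trypan blue exclusion and crystal violet staining, with a stated time of 72 h (a higher number here means a weaker inhibitor, a lower number a stronger inhibitor), compound 1 gives 100 nM, the lowest of the two numbers recorded. Compound 2 `CCCCC(=O)NC(c1ccc(Cl)c(Cl)c1)c1ccc2cccnc2c1O` carries its chlorines on a different pattern and in this assay compound 2 gives 320 nM, which lies beyond the scatter from compound 1; the two are not linked by a single-site step, so the gap says only what the two values show. Compound 3 `CCCCC(=O)NCc1ccc2cccnc2c1O` has no result in this assay, where compound 3 is recorded as "nd" (no result reported). Compound 4 `CCCC(=O)NC(c1ccccc1)c1cc(Cl)c2cccnc2c1O` differs from compound 1 in one place: hydrogen in place of chloro on an aromatic carbon, read one bond further out as 2-chlorophenyl to phenyl. Among the measured compounds shown here, no measured pair shows this change, so the expectation rests on the spread of the two numbers. A modest loss is expected, with a 2.5-fold higher number from compound 1 to compound 4 (0.40 log units; beyond the scatter) estimated to fall outside the scatter but short of the gap to compound 2. Compound 4 is therefore estimated at 250 nM, within 80 nM to 800 nM.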

Compound 4, half-maximal inhibitory concentration: 130 nM
For compound 4 the middle estimate is 1.9-fold (0.28 log units) above the measured one; the range from low to high includes it.
By their numbers in this assay, from the lowest: compounds 1 and 4 (each within the scatter of the next); then compound 2.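

In this assay, among the compounds shown here, replacing the chloro with hydrogen gives a 1.3-fold higher number from compound 1 to compound 4 (0.11 log units; within the scatter), the first single-site step in the set. At this place, on an aromatic carbon ortho to a large group, 2-chlorophenyl and phenyl therefore cannot be told apart in this read-out, so the chloro is not required for the activity of this pair. No measurement at hand bears on why the step is so small.

Going by these compounds, whether a methoxy group, a trifluoromethyl group or an amine at the same place would also stay within the scatter remains open. The chloro on the core of compound 1 and the length of the amide chain have no single-site comparison among these compounds, so their contributions remain unresolved.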